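The source may report more compounds than this note shows. Statements on the series, on what has been measured and on what is new or still open speak of the compounds shown alone.

Working notes on a small diarylmethane and diarylmethanol set examined in a functional assay on A549 cells (Homo sapiens) for cytotoxicity, read by XTT assay, with a stated time of 72 h; on this read-out lower numbers stand for stronger inhibition and higher numbers for weaker inhibition.

Compound 1 `COc1ccc(C(O)c2ccc3c(ccn3C)c2)c(OC)c1OC` returns only a limit in this assay, > 10000 nM. Compound 3 `COc1ccc(C(O)c2ccc3ccccc3c2)c(OC)c1OC` likewise gives a limit in this assay, > 10000 nM. Compound 2 `COc1ccc(Cc2ccc(OC)c(OC)c2OC)cc1[N+](=O)[O-]`, the parent of the step followed here, is also reported in this assay as a limit, > 10000 nM. Compound 2 therefore stands where every measured member stands, on (the limit of > 10000 nM in this assay, at which 3 of the 3 values shown sit); no number separates it from compound 1 or compound 3.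

Compound 4 `COc1ccc(Cc2ccc(OC)c(OC)c2OC)cc1N` is still to be measured in this assay. It differs from compound 2 by amino in place of nitro on an aromatic carbon. Going by the values given here, no measured pair in the set shows what this change does, so the expected step is set to none beyond the scatter: a step of a number no higher from compound 2 to compound 4 (the limit leaves the size open) is expected, with the most likely outcome that compound 4 again returns only a limit, because compound 2 sits on (the limit of > 10000 nM in this assay, at which 3 of the 3 values shown sit). Compound 4 is estimated at 10000 nM in this assay, within 2000 nM to 30000 nM, with a real chance that it is reported as a limit rather than a number.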

Compound 4, half-maximal inhibitory concentration: 2700 nM
Compound 4: middle estimate off by 3.7-fold (0.57 log units), on the high side, and the stated range covers the measured number.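

Amino in place of nitro on this aromatic carbon, ortho to a methoxy group and meta to a large group, gives an at least 3.7-fold lower number from compound 2 to compound 4 (0.56 log units; beyond the scatter) in this assay. Going by these compounds alone, this position on the shared core is thus one where a single change moves the read-out beyond the scatter, which the earlier compounds could not show. Compound 4 is the only member shown that returns a number, and the other values sit at a limit: the limit of > 10000 nM in this assay, at which 3 of the 4 values shown sit.

Whether the lower number needs the free amino group remains open, since a hydroxyl, an acetamide or a dimethylamino group at the same place is not among the compounds shown. Whether the same exchange would lower the number on the diarylmethanol cores of compound 1 and compound 3 also cannot be told from this single pair.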